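Moving the acetyl group on the anilino ring

The source may hold more compounds than are shown below. What is called first, only, known or untested is meant among the compounds shown, and "the series" means these compounds.

Of the compounds shown here, three sharing one core have been measured in a functional assay on MDA-MB-468 cells (Homo sapiens) for inhibition, read by sulforhodamine B assay, with a stated time of 48 h, tested at 10 uM; on this read-out lower numbers stand for less inhibition of growth and higher numbers for more inhibition of growth at the one concentration tested. Compound 1 `CCOC(=O)c1ccc(Nc2ccnc(SCC(=O)c3ccc(C#N)cc3)n2)cc1` gives 52% in this assay. Compound 3 `COc1ccc(C(=O)CSc2nccc(Nc3cccc(C(C)=O)c3)n2)cc1` gives 34%. Compound 2 `CC(=O)c1cccc(Nc2ccnc(SCC(=O)c3ccc(-c4ccccc4)cc3)n2)c1` gives 14%, the lowest of the three numbers: compound 3 sits closest to it, beyond the scatter, and compound 1 furthest away, also beyond the scatter. For the measured compounds named here, the one single-point change among the measured compounds, a number 20 percentage points higher from compound 2 to compound 3 (beyond the scatter), alters the ring at the far end of the thioether chain, not the anilino side.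

Compound 4 `CC(=O)c1ccc(Nc2ccnc(SCC(=O)c3ccc(-c4ccccc4)cc3)n2)cc1` has not yet been measured. It differs from compound 2 only in where the acetyl group sits on the anilino ring: 4-acetylphenyl in place of 3-acetylphenyl on a nitrogen on an aromatic ring. Going by the values given here, no measured step touches this position, so nothing among the three compounds bears directly on it; the step from compound 2 to compound 3 concerns a different part of the molecule and is only a reminder that single changes here can shift this read-out by a modest amount. With no direct evidence, a small step in either direction, or none beyond the scatter, is expected, a number 11 percentage points higher from compound 2 to compound 4 (beyond the scatter). Compound 4 is therefore estimated at 25% in this assay, within a range of 5% to 50%.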

Compound 4, percent growth inhibition at one concentration: 13%
Estimate against measurement, compound 4: 12 percentage points above, and the stated range covers the measured number.
By their numbers in this assay, from the lowest: compounds 4 and 2 (each within the scatter of the next); then compound 3; then compound 1.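

In this assay, the move to 4-acetylphenyl in place of 3-acetylphenyl on a nitrogen on an aromatic ring gives a number 1 percentage points lower from compound 2 to compound 4 (within the scatter). For the compounds shown here, this is the first direct look at the anilino side of these molecules, and it shows that, with the biphenyl-type ketone end of compound 2 held constant, this read-out does not separate the two placements of the acetyl group, even though the ring is joined differently. The two groups have the same atoms and the same counts of donors and acceptors, so the comparison isolates placement alone, but no independent measurement is available to explain the outcome.

The compounds shown leave open whether the placement of the acetyl group would matter with methoxy in place of phenyl at the far end of the thioether chain, as in compound 3, where the number is already different. They also leave open what happens when the acetyl group itself gives way to another group on the anilino ring, such as a carboxylic acid, an amine or a longer chain ending in an amide.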